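Phenyl for methyl on the sulfinyl sulfur of compound 3

A few compounds are considered here, and "the series" means these few. Any claim that something is new, unique, unknown or untested is made for them only; others in the source may bear on it.

Compound 3 `CS(=O)(=NC(F)(F)F)c1ccccc1` gives in a functional assay on HepG2 cells (Homo sapiens) for cytotoxicity, read by MTT assay, with a stated time of 6 h (a higher number here means a weaker inhibitor, a lower number a stronger inhibitor), only a limit, > 200 ug/mL, so no number stands for it. Compound 1 `CS(=O)(=NSC(F)(F)F)c1ccccc1` gives 15 ug/mL, and the step of an at least 13-fold higher number from compound 1 to compound 3 (1.12 log units; beyond the scatter) reaches (the limit of > 200 ug/mL in this assay, at which 1 of the 3 values shown sits). Compound 2 `O=S(=NSC(F)(F)F)(c1ccccc1)c1ccccc1` gives 90 ug/mL. The change from compound 3 to compound 4 `O=S(=NC(F)(F)F)(c1ccccc1)c1ccccc1` is phenyl in place of methyl on a sulfinyl sulfur. The same change has been measured once in this series, as a 6.0-fold higher number from compound 1 to compound 2 (0.78 log units; beyond the scatter), a higher number of modest size. Starting from a limit, the expected step that the limit leaves unreadable from compound 3 to compound 4 cannot be read as a number, and a limit is expected to be reported again. Compound 4 is estimated at 500 ug/mL, with a range from 200 ug/mL to 1500 ug/mL.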

Compound 4, half-maximal inhibitory concentration: 200 ug/mL
Estimate against measurement, compound 4: 2.5-fold (0.40 log units) above; measured number inside the range.
By their numbers in this assay, from the lowest: compound 1; then compound 2; then compound 4.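

In this assay, trifluoromethyl in place of (trifluoromethyl)sulfanyl on a sulfonamide nitrogen now has a readable size on a second core (a 2.2-fold higher number from compound 2 to compound 4 (0.35 log units; beyond the scatter)). The two steps for this change do not match: the same change on two cores in this assay, an at least 13-fold higher number (1.12 log units; beyond the scatter) from compound 1 to compound 3 and a 2.2-fold higher number (0.35 log units; beyond the scatter) from compound 2 to compound 4, at least 6.0-fold (0.77 log units) apart, beyond the scatter of two such steps. Phenyl in place of methyl on a sulfinyl sulfur gives a number no higher from compound 3 to compound 4 (the limit leaves the size open) and so has no readable size on the trifluoromethyl side, yet the comparison still separates the two cores: the same change on two cores in this assay, a 6.0-fold higher number (0.78 log units; beyond the scatter) from compound 1 to compound 2 and a number no higher (the limit leaves the size open) from compound 3 to compound 4, at least 6.0-fold (0.77 log units) apart, beyond the scatter of two such steps.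

Open, as far as these compounds go, is whether a longer chain such as pentafluoroethyl, or an acetyl group, on the sulfonamide nitrogen would follow trifluoromethyl or (trifluoromethyl)sulfanyl in this assay.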